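The source may hold more compounds than are shown below. What is called first, only, known or untested is meant among the compounds shown, and "the series" means these compounds.

In an ADME assay on HEK293 cells (Homo sapiens) for cytotoxicity, read by resazurin assay, with a stated time of 72 h (on this read-out lower numbers stand for higher toxicity in this test and higher numbers for lower toxicity in this test), compound 1 `CCc1cccc(CNC(=O)c2nc3c(F)ccc(COCc4ccc(C(=O)O)cc4)c3c(=O)[nH]2)c1` gives > 20000 nM as a limit of the assay. Compound 2 `CCc1cccc(CNC(=O)c2nc3c(Cl)ccc(COCc4ccc(C(=O)O)cc4)c3c(=O)[nH]2)c1` likewise gives > 20000 nM as a limit and not a number. For the measured compounds named here, the only measured step is a step that the two limits leave unreadable from compound 1 to compound 2 and it has no size that can be read. Compound 3 `CCc1cccc(CNC(=O)c2nc3c(OC)ccc(COCc4ccc(C(=O)O)cc4)c3c(=O)[nH]2)c1` follows through methoxy in place of chloro on an aromatic carbon with methoxy in place of chloro on an aromatic carbon. Because the limit of > 20000 nM in this assay, at which 2 of the 2 values shown sit, offers no size to carry over, no step beyond the scatter is expected in this assay for this change. The expected step that the limit leaves unreadable from compound 2 to compound 3 is an estimate only. For compound 3 the estimated value is 25000 nM with an expected range from 12000 nM to 50000 nM on this read-out.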

Compound 3, half-maximal cytotoxic concentration: > 20000 nM
Compound 3 gave a limit, no number; the forecaster's own chance of this, stated with the estimate: 85%; the middle value does not contradict the limit.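

No step can be read among compound 1, compound 2 and compound 3, because each gives a limit and not a number: the limit of > 20000 nM in this assay, at which 3 of the 3 values shown sit. On these data alone, whether fluoro, chloro and methoxy differ at all in this assay stays open.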